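Threonine amides with long alkyl chains: cytotoxicity notes

The source may report more compounds than this note shows. Statements on the series, on what has been measured and on what is new or still open speak of the compounds shown alone.

Measured so far:
- compound 1 `CCCCCCCCCCCCCCCCCCNC(=O)[C@@H](N)[C@@H](C)O`: 21400 nM
- compound 2 `CCCCCCCCNC(=O)[C@@H](NC(=O)/C=C/c1ccccc1)[C@@H](C)O`: 61400 nM

In a functional assay on SW-620 cells (Homo sapiens) for cytotoxicity, read by MTT assay, with a stated time of 48 h (a higher number here means a weaker inhibitor, a lower number a stronger inhibitor), compound 1 gives 21400 nM. In this assay compound 2 gives 61400 nM, the higher of the two numbers; the gap between compound 2 and compound 1 lies beyond the usual scatter, but the two structures differ in more than one place, so the gap is recorded without further reading.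

Compound 3 `CCCCCCCCCCCCNC(=O)[C@@H](NC(=O)/C=C/c1ccccc1)[C@@H](C)O` differs from compound 2 only in the alkyl chain: butyl in place of hydrogen on a saturated chain carbon, eight bonds along the chain from an amide-type nitrogen. Among the measured compounds shown here, no measured pair isolates such a change. The lone hint is that compound 1, which carries the longest chain, gives the lower number of the two, but its other differences prevent any firm inference. A modest step downward, near the edge of the scatter, is expected, a 1.9-fold lower number from compound 2 to compound 3 (0.28 log units; within the scatter). Compound 3 is therefore estimated at 32000 nM, within 10000 nM to 90000 nM.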

Compound 3, half-maximal inhibitory concentration: 200000 nM
The estimate for compound 3 lay 6.3-fold (0.80 log units) below the measured number; measured number above the stated range.
By their numbers in this assay, from the lowest: compound 1; then compound 2; then compound 3.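

In this assay, butyl in place of hydrogen on a saturated chain carbon, eight bonds along the chain from an amide-type nitrogen, gives a 3.3-fold higher number from compound 2 to compound 3 (0.51 log units; beyond the scatter), so this position is not indifferent to the change and the added carbons weaken inhibition on this core. Among the compounds shown here, this is the first one-place comparison, and it runs upward; compound 1, with the longest chain and the lowest number, differs from both in more than one place, so it neither supports nor opposes this reading. Nothing measured here bears on the reason for the step.

A single step gives a direction for one pair only, not a trend with chain length. Going by these compounds, whether a longer chain on this core continues the rise, or a carboxylic acid in place of butyl at this position behaves differently, remains open.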